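From Hydroxy to Acetyl in a Weakly Cytotoxic Pair

The source may hold more compounds than are shown below. What is called first, only, known or untested is meant among the compounds shown, and "the series" means these compounds.

Compound 1 `Cc1ccc(NC(=O)CSC(=S)N[C@H]2CCOC2=O)cc1` carries a methyl on the aromatic carbon, and in a functional assay on EC9706 cells (Homo sapiens) for cytotoxicity, read by MTT assay, with a stated time of 72 h (a lower number here means a stronger inhibitor, a higher number a weaker inhibitor), compound 1 gives 93900 nM. Compound 2 `O=C(CSC(=S)N[C@H]1CCOC1=O)Nc1ccc(O)cc1` bears a hydroxy in that place instead. In this assay compound 2 reaches only a limit, > 128000 nM. The measured step of an at least 1.3-fold higher number from compound 1 to compound 2 (0.13 log units; that floor lies within the scatter) thus shows no more than a drift toward a higher number whose floor sits within the scatter; the limit itself is recorded as the limit of > 128000 nM in this assay, at which 1 of the 2 values shown sits. Compound 3 `CC(=O)c1ccc(NC(=O)CSC(=S)N[C@H]2CCOC2=O)cc1` differs from compound 2 by acetyl in place of hydroxy on an aromatic carbon. For the measured compounds named here, no measured step involves an acetyl, so the expectation rests only on the two weak values shown. Compound 3 is therefore expected to remain in the same weak region, with an estimated value of 110000 nM (from 40000 nM to 250000 nM). That estimate means a step of an at least 1.1-fold lower number from compound 2 to compound 3 (0.06 log units; that floor lies within the scatter), which is expected to stay within the scatter.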

Compound 3, half-maximal inhibitory concentration: > 128000 nM
Compound 3: no number, only a limit; the forecaster's own chance of this, stated with the estimate: 40%; middle value at least 1.1-fold (0.06 log units) from the limit.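

In this assay compound 3 gives > 128000 nM as a limit of the assay and not a number, and since compound 2 also stands at a limit, the step between these two cannot be read. Acetyl, with its three heavy atoms and no hydrogen-bond donor, therefore cannot be ranked against hydroxy at this place, on an aromatic carbon para to a large group. Set against methyl, the change gives an at least 1.3-fold higher number from compound 1 to compound 3 (0.13 log units; that floor lies within the scatter) and so shows no shift beyond the scatter, while the limit now holds most of the small set: the limit of > 128000 nM in this assay, at which 2 of the 3 values shown sit.

Going by these compounds, only methyl has so far given a number at this place, so it remains open whether any group here can give a clearly lower value. On these data alone, how an amine or a carboxylic acid at this place would read also stays open.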